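Amide to ester swap at the carbonyl carbon

The compounds below may be only part of what the source reports. "The series", "measured", "known", "first", "only" and "open" are said of these compounds alone.

Measured so far:
compound 1 `CCn1c(C(=O)NCCCN(C)C)ccc1C(CC)(CC)c1ccc(OCC(O)C(C)(C)C)c(C)c1` — 37 nM
compound 2 `CCn1c(C(=O)NCC(OC)OC)ccc1C(CC)(CC)c1ccc(OCC(O)C(C)(C)C)c(C)c1` — 150 nM

In an assay on HL-60 cells for agonist activity at vitamin D3 receptor (Homo sapiens), read by microscopy, with a stated time of 96 h (a lower number here means that less compound is needed, a higher number that more compound is needed for the effect), compound 1 gives 37 nM. In this assay, going by the values given here, compound 2 gives 150 nM, the highest of the two numbers; the only step between them, a 4.1-fold higher number from compound 1 to compound 2 (0.61 log units; beyond the scatter), is beyond the scatter.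

Compound 3 `C#CCCOC(=O)c1ccc(C(CC)(CC)c2ccc(OCC(O)C(C)(C)C)c(C)c2)n1CC` is not yet measured. It differs from compound 2 by (but-3-yn-1-yl)oxy in place of (2,2-dimethoxyethyl)amino on a carbonyl carbon. Among the compounds with values here, no measured step touches this position in the same way: the single step, from compound 1 to compound 2, exchanges one amide substituent for another and moves the number by a modest amount. Nothing shown covers removal of the amide hydrogen or the entry of an ester. The expectation is therefore set near compound 2 with a wide range: compound 3 is estimated at 120 nM, between 30 nM and 500 nM. That estimate means an expected step of a 1.3-fold lower number from compound 2 to compound 3 (0.10 log units; within the scatter).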

Compound 3, half-maximal effective concentration: 1030 nM
Estimate against measurement, compound 3: 8.6-fold (0.93 log units) below; measured number above the stated range.
By their numbers in this assay, from the lowest: compound 1; then compound 2; then compound 3.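

In this assay putting (but-3-yn-1-yl)oxy in place of (2,2-dimethoxyethyl)amino on the carbonyl carbon gives a 6.9-fold higher number from compound 2 to compound 3 (0.84 log units; beyond the scatter) and shows that an exchange of the amide for an ester at this position is not neutral in this series. Set against the (3-(dimethylamino)propyl)amino group, the same ester gives a 28-fold higher number from compound 1 to compound 3 (1.44 log units; beyond the scatter) and leaves compound 3 with the highest number of the three, so both amides shown sit lower than this ester. No measurement at hand accounts for the rise.

The change replaces the linking nitrogen and the chain together, so their shares stay unseparated. Open, going by these compounds, is whether an amide carrying but-3-yn-1-yl, a 2,2-dimethoxyethyl ester, or a carboxylic acid on this carbonyl carbon would lie closer to compound 2 or to compound 3.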